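Replacing the nitrophenyl group on a sulfamoylphenyl scaffold

The source may report more compounds than this note shows. Statements on the series, on what has been measured and on what is new or still open speak of the compounds shown alone.

Among the compounds with values here, compound 2 `N#CC1=C(N)N(c2ccc(S(N)(=O)=O)cc2)C2=C(C(=O)CCC2)C1c1ccc([N+](=O)[O-])cc1` gives the higher of the two numbers known so far: in a functional assay on Ehrlich cells (Mus musculus) for antiproliferative activity, read by trypan blue exclusion, with a stated time of 2 h, tested at 50 ug/mL (a lower number here means a weaker effect, a higher number a stronger effect of the compound at the concentration tested), compound 2 gives 95%, while compound 1 `N#CC1=C(N)N(c2ccc(S(N)(=O)=O)cc2)C2=C(C(=O)CCC2)C1c1ccccc1` gives 40% in this assay. Within the data shown here, the only step with a measurement is the one between them, a number 55 percentage points higher from compound 1 to compound 2 (beyond the scatter). Compound 3 `COc1ccc2ccccc2c1C1C(C#N)=C(N)N(c2ccc(S(N)(=O)=O)cc2)C2=C1C(=O)CCC2` has not been tested; it differs from compound 2 in one place (2-methoxynaphthalen-1-yl in place of 4-nitrophenyl on a saturated ring carbon). That change removes the nitro group that distinguishes compound 2 from compound 1, but puts in its place a group for which no measurement exists, so the step from compound 1 to compound 2 bears on it only in part. On that basis a drop is expected, though smaller than the full reverse of that step. For compound 3 the expected step is a number 40 percentage points lower from compound 2 to compound 3 (beyond the scatter). Compound 3 is therefore estimated at 55% in this assay, with a range from 25% to 85%.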

Compound 3, a percentage reported as activity, at one concentration (the size of the read-out at that concentration, not a potency): 70%
Compound 3: the middle estimate sits 15 percentage points below what was measured; low and high end bracket the measured number.
By their numbers in this assay, from the lowest: compound 1; then compound 3; then compound 2.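

At this saturated ring carbon, a group without a nitro also lifts the read-out over phenyl: in this assay, 2-methoxynaphthalen-1-yl in place of phenyl gives a number 30 percentage points higher from compound 1 to compound 3 (beyond the scatter). The nitro group is therefore not required for a gain over compound 1, yet 2-methoxynaphthalen-1-yl does not match 4-nitrophenyl, giving a number 25 percentage points lower from compound 2 to compound 3 (beyond the scatter). The data offer no explanation for the order of these three groups.

The compounds shown do not separate the contribution of the methoxy group from that of the second aromatic ring, which a plain naphthalen-1-yl or a 4-methoxyphenyl group would address. They also leave open how other groups at the same place of the phenyl ring, such as an amine or a carboxylic acid in place of the nitro, would read out.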